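The source may hold more compounds than are shown below. What is called first, only, known or untested is meant among the compounds shown, and "the series" means these compounds.

Measured so far in a physicochemical assay for solubility, at pH 7.4; a higher number here means a more soluble compound, a lower number a less soluble compound:
- compound 1 `CC(C)(C)c1cc(Nc2ccc(Cl)cc2Cl)ncc1C(=O)NCC1CCOCC1`: 23 ug/mL
- compound 2 `O=C(NCC1CCOCC1)c1cnc(Nc2ccc(Cl)c(Cl)c2)cc1C1CC1`: 6 ug/mL

Of these two numbers, compound 1 holds the higher, and the gap down to compound 2 lies beyond the scatter. The next compound to be measured is compound 3 `O=C(NCC1CCOCC1)c1cnc(Nc2ccc(Cl)cc2Cl)cc1C1CCCC1`. Relative to compound 1, it carries cyclopentyl in place of tert-butyl on an aromatic carbon, opposite the ring nitrogen (cyclopentyl in place of tert-butyl on an aromatic carbon). Among the measured compounds shown here, no measured step isolates a single change in this set, so the expectation in this assay is a judgement: a moderately lower number, possibly not beyond the scatter. For the measured compounds named here, the only guide is compound 2, which has no tert-butyl group and stands at 6 ug/mL, though it differs from compound 1 in more than one place. The estimated change is a 2.1-fold lower number from compound 1 to compound 3 (0.32 log units; beyond the scatter). For compound 3, the expected value is 11 ug/mL, with an estimated range of 4 ug/mL to 30 ug/mL.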

Compound 3, solubility: < 1 ug/mL
Compound 3 was reported as a limit (the forecaster's own chance of this, stated with the estimate: 8%); middle value at least 11-fold (1.04 log units) away from the limit.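

Cyclopentyl in place of tert-butyl on the aromatic carbon opposite the ring nitrogen gives an at least 23-fold lower number from compound 1 to compound 3 (1.36 log units; beyond the scatter) in this assay, the first change in this set confined to one place. The number at this position proves highly sensitive to the group it carries: one all-carbon group replacing another, with hydrogen-bond donors, acceptors and net charge unchanged, is enough for a large step. Compound 3 is reported as < 1 ug/mL, which is a limit of the assay and not a number, so the step has no known end: the limit of < 1 ug/mL in this assay, at which 1 of the 3 values shown sits.

The compounds shown do not separate the effect of the ring in cyclopentyl from that of its larger size. They also leave open how this position would respond to an amine such as dimethylamino, or to a carboxylic acid.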